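The source may report more compounds than this note shows. Statements on the series, on what has been measured and on what is new or still open speak of the compounds shown alone.

Two compounds share a common core and differ only in the group attached at one end of it. Compound 1 `CCCCCCCCCCc1ccc(-c2noc(CCCNC)n2)cc1` gives 45% in an assay on HeLa cells for inhibition of sphingosine-1-phosphate transporter SPNS2 (Mus musculus), read by LC-MS, tested at 2 uM; a lower number here means less inhibition, a higher number more inhibition at the concentration tested (going by the name of the read-out). Compound 2 `CCCCCCCCCCc1ccc(-c2noc(CC3CCNC3)n2)cc1` gives 44% in this assay. The step of a number 1 percentage points lower from compound 1 to compound 2 (within the scatter) lies within the scatter, so the two readings cannot be told apart. For the measured compounds named here, compound 2 thus stands at the lower of the two numbers so far, with compound 1 as its nearest neighbour and within the scatter of it.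

Compound 3 `CCCCCCCCCCc1ccc(-c2noc(C3CCNC3)n2)cc1` has not yet been measured. It differs from compound 2 as follows: pyrrolidin-3-yl in place of (pyrrolidin-3-yl)methyl on an aromatic carbon. Going by the values given here, the only measured step that bears on such an exchange is the one from compound 1 to compound 2, which stayed within the scatter; compound 3 keeps the same ring and the same counts of donor and acceptor as compound 2. For this reason no step beyond the scatter is expected, and the estimated step is a number 4 percentage points lower from compound 2 to compound 3 (within the scatter). Compound 3 is therefore expected to give about 40%, within a range from 25% to 55%, in this assay.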

Compound 3, a percentage reported as inhibition, at one concentration (the size of the read-out at that concentration, not a potency): 26%
Beside the measured number, compound 3's estimate is 14 percentage points above it; the measured number falls inside the stated range.
By their numbers in this assay, from the lowest: compound 3; then compounds 2 and 1 (each within the scatter of the next).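

In this assay, for the compounds shown here, setting pyrrolidin-3-yl directly on the aromatic carbon in place of (pyrrolidin-3-yl)methyl gives a number 18 percentage points lower from compound 2 to compound 3 (beyond the scatter), the first step in this set beyond the scatter, although both groups carry the same ring and the same counts of donors and acceptors. Replacing the open-chain 3-(methylamino)propyl with pyrrolidin-3-yl gives a step of similar size, a number 19 percentage points lower from compound 1 to compound 3 (beyond the scatter), whereas a number 1 percentage points lower from compound 1 to compound 2 (within the scatter) stays within the scatter, so among these three compounds the reading follows whether the ring sits directly on the aromatic carbon, not whether the amine lies in a ring or an open chain. Nothing available here accounts for this drop.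

The compounds shown leave open whether a longer chain linking the pyrrolidine ring to the shared core would keep the reading of compound 2, or whether the link of a single carbon is already enough. They also leave open how a piperidine ring, a tertiary amine or a carboxylic acid would read at this position, and so whether a ring nitrogen carrying a hydrogen matters here at all.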